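Series notes: methylation of the pyrrole nitrogen in compound 4

This account rests on a few compounds, and the source may have more. Where it says the series, first, only, none or still open, it means among the compounds named here.

Measured so far in a functional assay on PC-3 cells (Homo sapiens) for cytotoxicity, read by MTT assay, with a stated time of 72 h; a lower number here means a stronger inhibitor, a higher number a weaker inhibitor:
compound 1 `O=C(Nc1ccc(Oc2ccnc3[nH]ccc23)cc1)c1nn(-c2ccc(Br)cc2F)ccc1=O` gives 12800 nM
compound 2 `O=C(Nc1ccc(Oc2ccnc3[nH]ccc23)c(F)c1)c1nn(-c2ccc(Br)cc2F)ccc1=O` gives 8800 nM
compound 3 `O=C(Nc1ccc(Oc2ccnc3[nH]ccc23)c(F)c1)c1nn(-c2ccc(Cl)c(F)c2)ccc1=O` gives 13600 nM

Compound 2 is the reference point. Its neighbours differ from it only within the scatter: a 1.5-fold lower number from compound 1 to compound 2 (0.16 log units; within the scatter) and a 1.5-fold higher number from compound 2 to compound 3 (0.19 log units; within the scatter). For the measured compounds named here, all three numbers therefore sit in one band in this assay, and no compound can be called more or less potent than another on this evidence.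

Compound 4 `Cn1ccc2c(Oc3ccc(NC(=O)c4nn(-c5ccc(Br)cc5F)ccc4=O)cc3F)ccnc21` differs from compound 2 in one place: methyl in place of hydrogen on an aromatic nitrogen. Going by the values given here, none of the measured steps touches this position; the two known steps concern a fluoro on a benzene ring and the exchange of one halogenated phenyl for another, and both stayed inside the scatter. There is thus no measured guide for the size or direction of this change, and the expectation for compound 4 rests on the band the three compounds occupy.

The estimate for compound 4 in this assay is 15000 nM, with an expected range from 5000 nM to 50000 nM. The expected step is a 1.7-fold higher number from compound 2 to compound 4 (0.23 log units; within the scatter), stated with a wide range, since nothing measured bears on it.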

Compound 4, half-maximal inhibitory concentration: 16300 nM
For compound 4 the middle estimate is 1.1-fold (0.04 log units) below the measured one, within the range that was stated.
By their numbers in this assay, from the lowest: compounds 2, 1, 3 and 4 (each within the scatter of the next).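

In this assay, for the compounds shown here, methyl in place of hydrogen on an aromatic nitrogen of the five-membered aromatic ring gives a 1.9-fold higher number from compound 2 to compound 4 (0.27 log units; within the scatter), the first measured step at this position. The hydrogen on this nitrogen can therefore be replaced by methyl without compound 4 leaving the band of the other compounds, and this step is no more readable than the earlier changes on the benzene ring and the halogenated phenyl. Nothing available explains the size of this step or gives a reason for it.

As far as these compounds go, whether this nitrogen tolerates more than a single carbon stays open: a longer chain such as n-butyl, or a chain ending in an amine or a carboxylic acid, could give a different result. From the compounds shown here alone, it also remains unknown whether any group at this position can produce a step beyond the scatter in this assay.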